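Ester alcohol swaps and plasma half-life in the series

The compounds below may be only part of what the source reports. "The series", "measured", "known", "first", "only" and "open" are said of these compounds alone.

Compound 1 `NCc1ccc(C(=O)Nc2ccncc2F)cc1-c1cccc(C(=O)Oc2ccccc2)c1` carries a phenyl on the ester oxygen. Among the measured compounds shown here, in an ADME assay on a cell-free system (plasma, Homo sapiens) for metabolic stability, read by LC-MS (a higher number here means that the compound lasts longer, a lower number that the compound disappears faster), compound 1 gives 0.117 h, the lowest of the three numbers so far. Compound 2 `CCCOC(=O)c1cccc(-c2cc(C(=O)Nc3ccncc3F)ccc2CN)c1` gives 0.317 h and compound 3 `NCc1ccc(C(=O)Nc2ccncc2F)cc1-c1cccc(C(=O)OC2CCCOC2)c1` gives 0.3 h. Both replace that phenyl on an oxygen next to a carbonyl group with a non-aromatic carbon group: a 2.7-fold higher number from compound 1 to compound 2 (0.43 log units; beyond the scatter) and a 2.6-fold higher number from compound 1 to compound 3 (0.41 log units; beyond the scatter). Between the two, a 1.1-fold lower number from compound 2 to compound 3 (0.02 log units; within the scatter), so the two replacements read alike.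

Compound 4 `NCc1ccc(C(=O)Nc2ccncc2F)cc1-c1cccc(C(=O)OCC2CCCC2)c1` is not yet measured. Its change from compound 1: cyclopentylmethyl in place of phenyl on an oxygen next to a carbonyl group. The same place, the same loss of the phenyl and again a non-aromatic carbon group entering, as in the steps to compound 2 and compound 3. A modest rise of about the size of those two steps is therefore expected, namely a 2.6-fold higher number from compound 1 to compound 4 (0.41 log units; beyond the scatter). Compound 4 is expected to give 0.3 h in this assay, with a range of 0.15 h to 0.6 h. Only these three compounds support the expectation; cyclopentylmethyl itself has not been measured anywhere in the set.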

Compound 4, half-life: 0.283 h
For compound 4 the middle estimate is 1.1-fold (0.03 log units) above the measured one, within the range that was stated.
By their numbers in this assay, from the lowest: compound 1; then compounds 4, 3 and 2 (each within the scatter of the next).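

With cyclopentylmethyl, the rise on losing the phenyl from the ester oxygen holds for a third non-aromatic group, with a 2.4-fold higher number from compound 1 to compound 4 (0.38 log units; beyond the scatter) in this assay. The new group also reads alike with the other two, with a 1.1-fold lower number from compound 3 to compound 4 (0.03 log units; within the scatter) and a 1.1-fold lower number from compound 2 to compound 4 (0.05 log units; within the scatter), so a five-membered carbon ring on a saturated chain carbon, the oxan-3-yl ring and the open propyl chain cannot be told apart here, and only the phenyl of compound 1 stands apart among the four compounds. No measurement at hand explains this shared level.

Open, as far as these compounds go, is whether benzyl, which keeps an aromatic ring on a saturated chain carbon, would read with compound 1 or with the other three. Also open, from the compounds shown here alone, is whether a tert-butyl or a 2-aminoethyl group on this oxygen would leave the number in the same range.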